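Working notes: from compound 3 to compound 4

The source may report more compounds than this note shows. Statements on the series, on what has been measured and on what is new or still open speak of the compounds shown alone.

In a functional assay on MCF7 cells (Homo sapiens) for inhibition, read by MTT assay, with a stated time of 48 h, tested at 10 uM (on this read-out lower numbers stand for less inhibition of growth and higher numbers for more inhibition of growth at the one concentration tested), the measured compounds read:
- compound 1 `COc1ccc(COc2cc(O)c3c(=O)cc(C)oc3c2[C@H]2CCN(C)C[C@H]2O)cc1` gives 16%
- compound 2 `Cc1oc2c([C@H]3CCN(C)C[C@H]3O)c(O)cc(O)c2c(=O)c1C(O)c1ccc([N+](=O)[O-])cc1` gives 4%
- compound 3 `CN1CC[C@H](c2c(O)cc(O)c3c(=O)cc(/C=C/c4ccc(Cl)cc4)oc23)[C@H](O)C1` gives 10%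

Compound 3 lies within the scatter of both compound 1 and compound 2, so these three values are not separated. Compound 4 `CN1CC[C@H](c2c(O)cc(O)c3c(=O)cc(/C=C/c4ccccc4F)oc23)[C@H](O)C1` carries 2-fluorophenyl in place of 4-chlorophenyl on a double-bonded chain carbon bound to a double-bonded chain carbon.

Among the measured compounds shown here, no measured pair isolates this change. In this assay no step beyond the scatter is expected, in either direction, and the expectation rests on compound 3 (10%). The expected step is small: a number 1 percentage points higher from compound 3 to compound 4 (within the scatter). The estimated value for compound 4 is 11% (range 1% to 25%).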

Compound 4, percent growth inhibition at one concentration: 62%
Compound 4: the middle estimate sits 51 percentage points below what was measured, outside the stated range (above it).
By their numbers in this assay, from the lowest: compounds 2, 3 and 1 (each within the scatter of the next, the first and the last beyond it); then compound 4.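

In this assay, the group on the double-bonded chain carbon can decide the read-out: 2-fluorophenyl in place of 4-chlorophenyl gives a number 52 percentage points higher from compound 3 to compound 4 (beyond the scatter). Among the compounds shown here, compound 1 and compound 2 differ from compound 3 in more than one place, so only this step ties a large change to this position. Nothing on hand gives a reason for the step.

Still open, from the compounds shown here alone, is what 2-chlorophenyl or 4-fluorophenyl would read here, which would separate the change of halogen from its placement. Also open, going by these compounds, is what a 2-methoxyphenyl group would read at this position.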